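Ring Size and Spacer at the Amine of Compound 2

A few compounds are considered here, and "the series" means these few. Any claim that something is new, unique, unknown or untested is made for them only; others in the source may bear on it.

Going by the values given here, compound 2 `N#Cc1cnc(NCc2cnccc2C(F)(F)F)cc1NC[C@H]1C[C@@H](O)C1` is the only compound here with a definite number in an assay on isolated protein for inhibition of protein kinase C delta type (Homo sapiens), read by TR-FRET, with a stated time of 2 h; a higher number here means a weaker inhibitor, a lower number a stronger inhibitor: compound 2 gives 4200 nM. Compound 1 `N#Cc1cnc(NCc2cnccc2C(F)(F)F)cc1N[C@H]1C[C@@H](O)C1` differs only in lacking the one-carbon spacer between the nitrogen and the four-membered ring. In this assay compound 1 reaches only a limit of the assay, > 10000 nM. On these data alone, the step of an at least 2.3-fold lower number from compound 1 to compound 2 (0.37 log units; beyond the scatter) shows that adding the spacer helped, though its full size is unknown because compound 1 sits at the limit of > 10000 nM in this assay, at which 1 of the 2 values shown sits.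

Compound 3 `N#Cc1cnc(NCc2cnccc2C(F)(F)F)cc1N[C@H]1CC[C@@H](O)CC1` again attaches the ring directly to the nitrogen, but the ring is larger: 4-hydroxycyclohexyl in place of (3-hydroxycyclobutyl)methyl on a nitrogen on an aromatic ring. Among the compounds with values here, no measured step covers a change of ring size; the only measured comparison concerns the spacer, and its absence went with the weaker number. A weakening step is therefore expected, a 2.1-fold higher number from compound 2 to compound 3 (0.33 log units; beyond the scatter). Compound 3 is estimated at 9000 nM, with a range from 3000 nM to 30000 nM, and a fair chance that only a limit is reported.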

Compound 3, half-maximal inhibitory concentration: 4500 nM
Compound 3: the middle estimate sits 2.0-fold (0.30 log units) above what was measured; measured number inside the range.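

A spacer is not needed for a definite number at this position: in this assay, a 4-hydroxycyclohexyl group placed directly on the nitrogen matches (3-hydroxycyclobutyl)methyl, with a 1.1-fold higher number from compound 2 to compound 3 (0.03 log units; within the scatter). Among the groups attached directly to the nitrogen, ring size also counts, since the six-membered ring in place of the four-membered one gives an at least 2.2-fold lower number from compound 1 to compound 3 (0.34 log units; beyond the scatter). Compound 1 gives only a limit of the assay, so the full size of that step stays unknown: the limit of > 10000 nM in this assay, at which 1 of the 3 values shown sits.

The compounds shown leave open whether a spacer would change the number on the six-membered ring, as a (4-hydroxycyclohexyl)methyl group would show. They also leave open how much the hydroxyl group itself contributes, which an amine in its place on the ring could begin to test.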